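A few compounds are considered here, and "the series" means these few. Any claim that something is new, unique, unknown or untested is made for them only; others in the source may bear on it.

Series notes. Compound 1 `CCC(CC)O[C@@H]1C=C([B-](F)(F)F)C[C@H](NC(=N)N)[C@H]1NC(C)=O`, compound 2 `CCC(CC)O[C@@H]1C=C(S(=O)(=O)CCc2ccncc2)C[C@H](N)[C@H]1NC(C)=O` and compound 3 `CCC(CC)O[C@@H]1C=C(S(=O)(=O)CCc2ccncc2)C[C@H](NC(=N)N)[C@H]1NC(C)=O` share one core and differ at the ring substituents. In an ADME assay on MDCK cells (Canis lupus familiaris) for cytotoxicity, with a stated time of 48 h (a lower number here means that less compound is tolerated, a higher number that more compound is tolerated), compound 1 gives "not determined" (no result reported) and compound 2 gives "not determined" (no result reported). Compound 3 in this assay gives > 100000 nM, which is a limit of the assay and not a number. Within the data shown here, compound 3 therefore sits at the limit of > 100000 nM in this assay, at which 1 of the 3 values shown sits, the only reading among the three. Compound 4 `CCC(CC)O[C@@H]1C=C(S(=O)(=O)OCCCc2ccccc2)C[C@H](NC(=N)N)[C@H]1NC(C)=O` is the unmeasured partner and differs from compound 3 by 3-phenylpropoxy in place of 2-(pyridin-4-yl)ethyl on a sulfonyl sulfur. Among the measured compounds shown here, no step between measured compounds exists here, so no size of step can be read from the data. The step is expected to be a number no higher from compound 3 to compound 4 (the limit leaves the size open), none beyond the scatter. Compound 4 is estimated at 100000 nM, between 40000 nM and 300000 nM.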

Compound 4, half-maximal cytotoxic concentration: > 100000 nM
Compound 4 gave a limit, no number (the forecaster's own chance of this, stated with the estimate: 75%); the middle value lies on the limit itself.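

In this assay no step can be read from compound 3 to compound 4, since each gives only a limit of the assay: the limit of > 100000 nM in this assay, at which 2 of the 4 values shown sit.
The compounds shown leave open what size of step, if any, comes with 3-phenylpropoxy in place of 2-(pyridin-4-yl)ethyl on a sulfonyl sulfur.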